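Trifluoromethyl for fluoro on the phenyl of a succinimide amide

The compounds below may be only part of what the source reports. "The series", "measured", "known", "first", "only" and "open" are said of these compounds alone.

Measured compounds:
compound 1 `CCC(C(=O)N1CCN(c2cccc(F)c2)CC1)N1C(=O)CCC1=O` 75%
compound 2 `CCC(C(=O)N1CCN(c2ccccc2F)CC1)N1C(=O)CCC1=O` 50%
compound 3 `CCC(C(=O)N1CCN(c2ccccc2C(F)(F)F)CC1)N1C(=O)CCC1=O` 0%

Three compounds were tested in a functional assay on the whole organism (strain Swiss) with Mus musculus as the target, in the maximal electroshock model, with a stated time of 1 h, at a dose of 300 mg/kg by the intraperitoneal route; on this read-out lower numbers stand for a weaker effect and higher numbers for a stronger effect at the one dose given. Compound 1 stands highest; compound 2 lies a number 25 percentage points lower from compound 1 to compound 2 (beyond the scatter), its core differing from that of compound 1 by 3-fluorophenyl in place of 2-fluorophenyl on an amine nitrogen in a ring. Compound 3 falls a number 50 percentage points lower from compound 2 to compound 3 (beyond the scatter), the change being (trifluoromethyl in place of fluoro on an aromatic carbon). Compound 4 `CCC(C(=O)N1CCN(c2cccc(C(F)(F)F)c2)CC1)N1C(=O)CCC1=O` is not yet measured; it differs from compound 1 by trifluoromethyl in place of fluoro on an aromatic carbon. This is the same kind of change as from compound 2 to compound 3, but the place is not the same: there the new group sits ortho to a large group, here meta to it. Because compound 2 to compound 3 showed a number 50 percentage points lower from compound 2 to compound 3 (beyond the scatter), a drop of similar size is expected, a number 50 percentage points lower from compound 1 to compound 4 (beyond the scatter), the different place leaving the size uncertain. Compound 4 is thus estimated at 25%, between 0% and 55%.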

Compound 4, a percentage reported as activity, at one dose (the size of the read-out at that dose, not a potency): 100%
Compound 4: middle estimate off by 75 percentage points, on the low side, and the stated range ends below it.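

In this assay, trifluoromethyl in place of fluoro on the core of compound 1 gives a number 25 percentage points higher from compound 1 to compound 4 (beyond the scatter). Set beside the earlier step, the change does not carry over from one core to the other, in either size or direction: the same change on two cores in this assay, a number 50 percentage points lower (beyond the scatter) from compound 2 to compound 3 and a number 25 percentage points higher (beyond the scatter) from compound 1 to compound 4, 75 percentage points apart, beyond the scatter of two such steps This shows that in this series the outcome of the change depends on the core that carries it, but with only one pair on each core it does not show why, nor whether the same holds at other doses.

The compounds shown leave open whether a chloro or a methoxy group on the same phenyl would follow compound 3 or compound 4. They also leave open how a nitrile would fare at either place.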